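The source may report more compounds than this note shows. Statements on the series, on what has been measured and on what is new or still open speak of the compounds shown alone.

Compound 1, `COc1ccc(-n2c(=O)n(Cc3cc4cc(Cl)ccc4n3CCCC#N)c3cnccc32)cc1`: > 50000 nM
Compound 2, `CC(C)CCn1c(Cn2c(=O)n(C3CC3)c3ccncc32)nc2ncccc21`: > 100000 nM

In an ADME assay on HeLa cells (Homo sapiens) for cytotoxicity, read by ATP content, with a stated time of 3 days (on this read-out lower numbers stand for higher toxicity in this test and higher numbers for lower toxicity in this test), compound 1 gives > 50000 nM, which is a limit of the test and not a measured number. Compound 2 gives > 100000 nM in this assay, again a limit rather than a number. Compound 1 thus stands at the limit of > 50000 nM in this assay, at which 1 of the 2 values shown sits, while the other value shown sits at the limit of > 100000 nM in this assay, at which 1 of the 2 values shown sits; neither compound has shown toxicity that the read-out could put a number on.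

Compound 3, `Cn1ccc(-n2c(=O)n(Cc3cc4cc(Cl)ccc4n3CCCC#N)c3cnccc32)n1`, has not yet been measured. It differs from compound 1 in one place: 1-methyl-1H-pyrazol-3-yl in place of 4-methoxyphenyl on an aromatic nitrogen. Within the data shown here, no step between two measured compounds is available, so no size of effect can be read from the data. The expected step is a number no higher from compound 1 to compound 3 (the limit leaves the size open), that is, none beyond the usual scatter. Compound 3 is therefore expected to give about 50000 nM in this assay, within 20000 nM to 100000 nM, and most likely to be reported again only as a limit.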

Compound 3, half-maximal cytotoxic concentration: > 50000 nM
Compound 3: only a limit was reported; the forecaster's own chance of this, stated with the estimate: 80%; the middle value lies on the limit itself.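

Among these compounds, compound 1 and compound 3 are both reported only as limits in this assay, and no step between them can be read. The compounds shown leave open whether 1-methyl-1H-pyrazol-3-yl in place of 4-methoxyphenyl changes toxicity at all, and at what concentration any of them would give a measured number.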